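The source may hold more compounds than are shown below. What is called first, only, known or untested is meant among the compounds shown, and "the series" means these compounds.

Compound 1 `COc1ccc(OCCOCCNC2CCCC2)cc1`: 99100 nM
Compound 2 `O=C(O)c1ccccc1COc1ccc(OCCOCCNC2CCCC2)cc1`: > 100000 nM
Compound 3 `Nc1ccc(COc2ccc(OCCOCCNC3CCCC3)cc2)cc1`: 31700 nM

In a functional assay on SK-OV-3 cells (Homo sapiens) for inhibition, read by CCK-8 assay, with a stated time of 70 h (on this read-out higher numbers stand for weaker inhibition and lower numbers for stronger inhibition), compound 3 gives the lower of the two exact numbers, at 31700 nM. For compound 2, the entry > 100000 nM is a limit of the assay and not a number. The measured steps are a 3.1-fold lower number from compound 1 to compound 3 (0.50 log units; beyond the scatter) and an at least 3.1-fold lower number from compound 2 to compound 3 (0.49 log units; beyond the scatter). Compound 4 `Nc1cccc(COc2ccc(OCCOCCNC3CCCC3)cc2)c1` carries 3-aminophenyl in place of 4-aminophenyl on a saturated chain carbon bound to an oxygen on an aromatic ring. Neither measured step compares these two groups, and the only exact one, a 3.1-fold lower number from compound 1 to compound 3 (0.50 log units; beyond the scatter), adds a whole group yet remains modest. A smaller change is therefore expected here, with nothing beyond the scatter in the estimated 1.1-fold higher number from compound 3 to compound 4 (0.04 log units; within the scatter). For compound 4, the expected value is 35000 nM, with an estimated range of 15000 nM to 80000 nM.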

Compound 4, half-maximal inhibitory concentration: 10800 nM
The estimate for compound 4 lay 3.2-fold (0.51 log units) above the measured number; the measured number lies below the stated range.
By their numbers in this assay, from the lowest: compound 4; then compound 3; then compound 1. At a limit, above all of these: compound 2.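

Where the amino group sits matters on its own: 3-aminophenyl in place of 4-aminophenyl, with the same atoms, gives a step beyond the scatter (a 2.9-fold lower number from compound 3 to compound 4 (0.47 log units; beyond the scatter)). Set against hydrogen, 3-aminophenyl gives a larger step than 4-aminophenyl did (a 9.2-fold lower number from compound 1 to compound 4 (0.96 log units; beyond the scatter)), and the step against the 2-carboxyphenyl group is also wide (an at least 9.2-fold lower number from compound 2 to compound 4 (0.96 log units; beyond the scatter)). That last step has no exact size, since the entry for compound 2 is a limit and not a number: the limit of > 100000 nM in this assay, at which 1 of the 4 values shown sits.

The compounds shown leave open what 2-aminophenyl would give at this place. They also leave open whether 3-hydroxyphenyl or 3-carboxyphenyl would match 3-aminophenyl.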